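Swapping the aryl amine for cyclohexyl on a second core

The compounds below may be only part of what the source reports. "The series", "measured", "known", "first", "only" and "open" are said of these compounds alone.

Measured compounds:
compound 1, `CCCc1ccc(NC2=CC(=O)c3nc4n(c3C2=O)[C@H]2OC[C@@H](O)[C@H]2OC4)cc1`: 4990 nM
compound 2, `O=C1C=C(NC2CCCCC2)C(=O)c2c1nc1n2[C@H]2OC[C@@H](O)[C@H]2OC1`: > 16000 nM
compound 3, `CCCc1ccc(NC2=CC(=O)c3c(nc4n3[C@H]3OC[C@@H](O)[C@H]3OC4)C2=O)cc1`: 6030 nM

All three were tested in a functional assay on HeLa cells (Homo sapiens) for inhibition, read by sulforhodamine B assay; on this read-out lower numbers stand for stronger inhibition and higher numbers for weaker inhibition. Compound 1 gives 4990 nM in this assay. Compound 2 reaches only the limit of this assay, > 16000 nM, and so no number is known for it. Compound 3 is built from the same atoms as compound 1 joined differently; compound 3 gives 6030 nM. The difference between the two cores is not broken down here, and the two values lie within the usual scatter of each other.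

The step from compound 1 to compound 2 is cyclohexyl in place of 4-propylphenyl on an amine nitrogen. It produces an at least 3.2-fold higher number from compound 1 to compound 2 (0.50 log units; beyond the scatter), and this rests on (the limit of > 16000 nM in this assay, at which 1 of the 3 values shown sits).

Compound 4, `O=C1C(NC2CCCCC2)=CC(=O)c2c1nc1n2[C@H]2OC[C@@H](O)[C@H]2OC1`, has not yet been measured in this assay. It stands to compound 3 exactly as compound 2 stands to compound 1: cyclohexyl in place of 4-propylphenyl on an amine nitrogen. The two places are the same word for word, so this is the same change. Compound 3 starts from a value close to that of compound 1, so the change is expected to carry compound 4 a similar distance, a 3.6-fold higher number from compound 3 to compound 4 (0.56 log units; beyond the scatter), likely to the limit of this assay again, because the earlier step was an at least 3.2-fold higher number from compound 1 to compound 2 (0.50 log units; beyond the scatter). The estimate for compound 4 in this assay is therefore 22000 nM, with a range from 9000 nM to 60000 nM.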

Compound 4, half-maximal inhibitory concentration: > 16000 nM
Compound 4: a limit, no number (the forecaster's own chance of this, stated with the estimate: 70%); the middle value is on the limit's open side.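

In this assay compound 4 reaches a limit of the assay (> 16000 nM), so it has no number. Cyclohexyl in place of 4-propylphenyl on an amine nitrogen again gives a weaker result (an at least 2.6-fold higher number from compound 3 to compound 4 (0.42 log units; beyond the scatter)), which shows that the direction of the change carries over from one core to the other in these two pairs, and the two steps compare as follows: the same change on two cores in this assay, an at least 3.2-fold higher number (0.50 log units; beyond the scatter) from compound 1 to compound 2 and an at least 2.6-fold higher number (0.42 log units; beyond the scatter) from compound 3 to compound 4; the limit leaves it open whether they differ. This does not show how large either step really is or whether the two cores respond to the same degree, because both steps end at one boundary: the limit of > 16000 nM in this assay, at which 2 of the 4 values shown sit.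

With only 4-propylphenyl and cyclohexyl on this amine nitrogen, the compounds shown leave open whether the weaker result goes with the loss of the aromatic ring or the loss of the propyl chain. A plain phenyl group or a 4-propylcyclohexyl group on either core could separate these two parts of the change.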